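Fluoro to Methoxy on the Benzyl Group of Compound 3

The source may hold more compounds than are shown below. What is called first, only, known or untested is meant among the compounds shown, and "the series" means these compounds.

Compound 3 `Nc1cc(N)c2nc(-c3ccccc3)c(NCc3ccc(F)cc3)nc2c1` shares its core with compound 1 `Nc1cc(N)c2nc(-c3ccccc3)c(NCc3ccc(Cl)c(Cl)c3)nc2c1` and compound 2 `COc1ccc(CNc2nc3cc(N)cc(N)c3nc2-c2ccccc2)cc1OC`, the three differing only in the substituents on the benzyl group attached to the amine. In a functional assay on MCF7 cells (Homo sapiens) for inhibition, read by sulforhodamine B assay, with a stated time of 48 h (on this read-out higher numbers stand for lower toxicity in this test and lower numbers for higher toxicity in this test), compound 3 gives only a limit, < 100000 nM. Compound 1 likewise gives a limit, < 100000 nM. Compound 2 also gives a limit, < 100000 nM. The three steps among them, a step that the two limits leave unreadable from compound 1 to compound 2, a step that the two limits leave unreadable from compound 1 to compound 3 and a step that the two limits leave unreadable from compound 2 to compound 3, cannot be sized for that reason, which the limit of < 100000 nM in this assay, at which 3 of the 3 values shown sit, summarises: every value shown sits at the same limit.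

Compound 4 `COc1ccc(CNc2nc3cc(N)cc(N)c3nc2-c2ccccc2)cc1` is compound 3 with a single change: methoxy in place of fluoro on an aromatic carbon. For the measured compounds named here, no measured step shows a fluoro-to-methoxy exchange directly. The comparisons that come closest are the steps from compound 1 and compound 2 to compound 3, and both are unreadable, as is the step between compound 1 and compound 2. The measured steps therefore give no direction, and no step beyond the scatter is expected in this assay, the expected step being a step that the limit leaves unreadable from compound 3 to compound 4. Compound 4 is expected to give 30000 nM, between 5000 nM and 100000 nM, with a fair chance that this assay again reports only a limit.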

Compound 4, concentration lethal to 50% of the cells: 53700 nM
Compound 4: middle estimate off by 1.8-fold (0.25 log units), on the low side, within the range that was stated.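

No new step can be read for compound 4: its steps to compound 1, compound 2 and compound 3 all stay unreadable, because each of those three compounds gives only a limit: the limit of < 100000 nM in this assay, at which 3 of the 4 values shown sit.

The compounds shown leave open whether any of these benzyl substituents changes the read-out in this assay at all, and by how much.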